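The source may report more compounds than this note shows. Statements on the series, on what has been measured and on what is new or still open speak of the compounds shown alone.

Measured so far in a functional assay on K562 cells (Homo sapiens) for antiproliferative activity, read by CCK-8 assay, with a stated time of 72 h; a higher number here means a weaker inhibitor of growth, a lower number a stronger inhibitor of growth:
Compound 1 `CCC1C(=O)N(C)c2cnc(Nc3ccc(S(=O)(=O)NCC(C)C)cc3)nc2N1c1ccn(C)n1`: 7300 nM
Compound 2 `CCC1C(=O)N(C)c2cnc(-n3ccc4cc(F)ccc43)nc2N1c1ccn(C)n1`: 6070 nM
Compound 3 `CCCCNC(=O)c1ccc2c(ccn2-c2ncc3c(n2)N(c2ccn(C)n2)C(CC)C(=O)N3C)c1`: 14100 nM

Compound 3 and compound 1 lie within the scatter of each other, so these two cannot be ordered. Within the data shown here, the separation from compound 2 is clearer: the one measured step in the set is a 2.3-fold higher number from compound 2 to compound 3 (0.37 log units; beyond the scatter), and it comes with butylcarbamoyl in place of fluoro on an aromatic carbon.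

Compound 4 `CCC1C(=O)N(C)c2cnc(-n3ccc4cc(C(=O)NC5CCCC5)ccc43)nc2N1c1ccn(C)n1` differs from compound 3 in one place, with cyclopentyl in place of butyl on an amide-type nitrogen. Among the measured compounds shown here, no measured step changes the group on that nitrogen, so the evidence is indirect. The nearest guide is the step that brought in the whole butylcarbamoyl group, a 2.3-fold higher number from compound 2 to compound 3 (0.37 log units; beyond the scatter), which was only modest. Exchanging just the outer part of that group is therefore expected to produce no step beyond the scatter in this assay, and the data suggest no direction. The expected step is a 1.1-fold lower number from compound 3 to compound 4 (0.04 log units; within the scatter). For compound 4 the estimated value is 13000 nM. Its expected range runs from 6500 nM to 26000 nM.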

Compound 4, concentration for 50% growth inhibition: 31300 nM
Compound 4: the middle estimate sits 2.4-fold (0.38 log units) below what was measured; the whole stated range lies below it.
By their numbers in this assay, from the lowest: compounds 2, 1 and 3 (each within the scatter of the next, the first and the last beyond it); then compound 4.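

In this assay, the outer part of the carbamoyl group proves able to move the number on its own: cyclopentyl in place of butyl on an amide-type nitrogen gives a 2.2-fold higher number from compound 3 to compound 4 (0.35 log units; beyond the scatter), modest but beyond the scatter. The wider comparison also gains a second case, as the fluoro group gives way to cyclopentylcarbamoyl with a 5.2-fold higher number from compound 2 to compound 4 (0.71 log units; beyond the scatter), in the same direction as the change to butylcarbamoyl, a 2.3-fold higher number from compound 2 to compound 3 (0.37 log units; beyond the scatter), so both amides shown stand higher than the fluoro compound. No measurement offered here accounts for the difference between butyl and cyclopentyl on that nitrogen.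

With only these two groups on the nitrogen, the ring and the added carbon cannot be told apart, and a pentyl chain or a cyclobutyl ring would be needed to separate them. As far as these compounds go, it also remains open whether a methyl group, or a chain ending in an amine, would bring the number back towards that of compound 2 at 6070 nM.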